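Stereochemical inversion of the ring alcohol in compound 1

This account rests on a few compounds, and the source may have more. Where it says the series, first, only, none or still open, it means among the compounds named here.

Measured so far:
- compound 1, `O[C@H]1CCCc2nc(C#Cc3ccccc3)ccc21`, 9280 nM
- compound 2, `CC1(C)CCc2nc(C#Cc3ccccc3)ccc2C1=O`, 51 nM
- compound 3, `O=C1CCCc2nc(C#Cc3ccccc3)ccc21`, 800 nM

In an assay on isolated protein for displacement of a labelled ligand from metabotropic glutamate receptor 5 (Rattus norvegicus) (on this read-out higher numbers stand for weaker inhibition and lower numbers for stronger inhibition), compound 1 gives the highest of the three numbers. Its nearest neighbour is compound 3, whose ketone gives 800 nM; furthest away is compound 2 with 51 nM. Compound 4, `O[C@@H]1CCCc2nc(C#Cc3ccccc3)ccc21`, is the unmeasured partner of compound 1: the two compounds have the same atoms and bonds and differ only in configuration as drawn: 1 of 1 stereo elements differ; a stereocentre at a saturated ring carbon is drawn S in compound 1 and R in compound 4. Among the compounds with values here, no measured pair in the set shows what inverting this centre does, so the step has no direct precedent. Given that compound 1 gives 9280 nM while the ketone of compound 3 sits far lower, the opposite configuration is expected to move toward the ketone, and the step of a 6.2-fold lower number from compound 1 to compound 4 (0.79 log units; beyond the scatter) is estimated as a lowering beyond the scatter, with wide uncertainty. Compound 4 is therefore expected to give about 1500 nM, in the range 300 nM to 8000 nM.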

Compound 4, inhibition constant: 4710 nM
For compound 4 the middle estimate is 3.1-fold (0.50 log units) below the measured one, within the range that was stated.
By their numbers in this assay, from the lowest: compound 2; then compound 3; then compounds 4 and 1 (each within the scatter of the next).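

In this assay, inverting the ring alcohol centre gives a 2.0-fold lower number from compound 1 to compound 4 (0.29 log units; within the scatter), so this saturated ring carbon shows no dependence on configuration that can be read from this pair. The comparison isolates that centre: the fact that compounds 1 and 4 differ only in the configuration as drawn. Compound 4 at 4710 nM still stands well above compound 3 at 800 nM, so the gap between the ketone and the alcohol remains with either configuration.

Open, on these data alone, is what an amine or a methoxy group would give at this ring carbon. Also open, as far as these compounds go, is whether configuration stays this unimportant with the dimethyl substitution of compound 2.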